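Swapping the hydroxypropyl oxime ether for a benzyl one

The compounds below may be only part of what the source reports. "The series", "measured", "known", "first", "only" and "open" are said of these compounds alone.

Compound 1 `Cc1cc2c(F)c(Oc3ncnc(N)c3/C=N/OCCCO)ccc2[nH]1` holds the lowest of the two numbers obtained in a functional assay on A-375 cells (Homo sapiens) for antiproliferative activity (on this read-out higher numbers stand for weaker inhibition and lower numbers for stronger inhibition), giving 336 nM, while compound 2 `CO/N=C/c1c(N)ncnc1Oc1ccc2[nH]ccc2c1` gives 783 nM in this assay, a gap that lies beyond the scatter. Compound 3 `Cc1cc2c(F)c(Oc3ncnc(N)c3/C=N/OCc3ccccc3)ccc2[nH]1` differs from compound 1 by phenyl in place of 2-hydroxyethyl on a saturated chain carbon bound to an oxygen. Going by the values given here, no pair of measured compounds shows this kind of change, so the step in this assay is expected to be small, with no direction beyond the scatter. Compound 3 is therefore estimated at 280 nM in this assay, with a range from 80 nM to 1000 nM, which amounts to an expected step of a 1.2-fold lower number from compound 1 to compound 3 (0.08 log units; within the scatter).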

Compound 3, half-maximal inhibitory concentration: 62 nM
Compound 3: the middle estimate sits 4.5-fold (0.65 log units) above what was measured, outside the stated range (below it).
By their numbers in this assay, from the lowest: compound 3; then compound 1; then compound 2.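

On a saturated chain carbon bound to an oxygen, phenyl in place of 2-hydroxyethyl gives in this assay a clear change, a 5.4-fold lower number from compound 1 to compound 3 (0.73 log units; beyond the scatter). Going by these compounds alone, this is the first step read at this position, and it shows that the position responds to what it carries, with the benzyl group on the oxygen giving the lower number. No measurement at hand accounts for this step.

On these data alone, the two compounds differ in both the ring and the hydroxyl group, so the share of each stays open. As far as these compounds go, how a propyl chain, a cyclohexylmethyl group or a dimethylaminopropyl chain would read here also remains open.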